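This account rests on a few compounds, and the source may have more. Where it says the series, first, only, none or still open, it means among the compounds named here.

Working notes on the series.

Compound 1 `COc1ccc(-c2cc(=O)c3ccc(OC)cc3o2)cc1` is the weakest binder of the three measured here: in an in vitro assay on BTI-TN-5B1-4 cells for inhibition of Amine oxidase [flavin-containing] B (Homo sapiens) (a higher number here means a weaker inhibitor, a lower number a stronger inhibitor), compound 1 gives 49700 nM, the highest of the three numbers. The nearest number belongs to compound 3 `Fc1ccc(-c2cc(=S)c3ccc(F)cc3o2)cc1`, which in this assay gives 6890 nM; that gap lies beyond the scatter. The furthest number belongs to compound 2 `Cc1ccc(C2CC(=O)c3ccc(F)cc3O2)cc1`, which in this assay gives 160 nM, again well beyond the scatter. Within the data shown here, no pair among the measured compounds differs in a single place, so these gaps combine several changes at once and no single-point step is available.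

Compound 4 `COc1ccc(-c2cc(=O)c3ccc(F)cc3o2)cc1` is the next compound to be measured. It differs from compound 1 in one place: fluoro in place of methoxy on an aromatic carbon. Both compound 2 and compound 3 carry fluoro at that same position of the shared core and both return lower numbers than compound 1, although each also differs from compound 1 elsewhere, so the comparison is loose.

The expectation for compound 4 is a move toward a lower number than compound 1, of a size beyond the scatter, written as a 5.5-fold lower number from compound 1 to compound 4 (0.74 log units; beyond the scatter). The estimate for compound 4 in this assay is 9000 nM, with a range from 2000 nM to 35000 nM.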

Compound 4, half-maximal inhibitory concentration: 1340 nM
Compound 4: the middle estimate sits 6.7-fold (0.83 log units) above what was measured, and the stated range ends above it.
By their numbers in this assay, from the lowest: compound 2; then compound 4; then compound 3; then compound 1.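

Fluoro in place of methoxy at this position gives, in this assay, a 37-fold lower number from compound 1 to compound 4 (1.57 log units; beyond the scatter), so the position on the aromatic carbon meta to a fused ring and para to a fused ring is now shown on its own to carry a large effect on the number; compound 2 and compound 3 could only hint at this, as each differs from compound 1 in more than one place. The rest of compound 1 is unchanged in compound 4, so the whole step belongs to this one exchange, in which methoxy with its hydrogen-bond acceptor leaves and fluoro enters. Nothing measured alongside these numbers bears on the reason for the step, so the series gives its size and no explanation.

Among these compounds, with only two groups compared at this position, it remains open whether the lower number is particular to fluoro or would also appear with chloro, an amine or plain hydrogen at the same carbon. It also remains open whether the step would hold on the cores of compound 2 and compound 3, as neither has a methoxy partner differing in one place among the compounds shown.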